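The compounds below may be only part of what the source reports. "The series", "measured", "known", "first", "only" and "open" are said of these compounds alone.

Of the compounds shown here, three that share one core have been tested in a functional assay on HCT-116 cells (Homo sapiens) for cytotoxicity, read by MTT assay, with a stated time of 48 h; on this read-out higher numbers stand for weaker inhibition and lower numbers for stronger inhibition. Compound 1 `O=C(/C=C/c1ccc2c(c1)B(O)OC2)c1cccs1` gives 14200 nM, the highest number of the three. Compound 2 `CSc1ccc(C(=O)/C=C/c2ccc3c(c2)B(O)OC3)cc1` gives 10300 nM, a number that sits within the usual scatter of compound 1, so no order between them can be read. Compound 3 `O=C(/C=C/c1ccc2c(c1)B(O)OC2)c1ccc(Cl)c(Cl)c1` gives 3200 nM, which lies beyond the scatter and clearly below compound 1.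

Compound 4 `Cc1cccc(C(=O)/C=C/c2ccc3c(c2)B(O)OC3)c1` has not yet been measured in this assay. It differs from compound 1 in one place: 3-methylphenyl in place of thiophen-2-yl on a carbonyl carbon. Among the measured compounds shown here, no measured pair shows this exact change, so the step can only be guessed from the spread of the three numbers, which run from the value of compound 1 down to that of compound 3. A small lowering, of a size near the edge of the scatter, is expected for compound 4 in this assay, an expected step of a 1.8-fold lower number from compound 1 to compound 4 (0.25 log units; within the scatter). Compound 4 is therefore estimated at 8000 nM, with a range from 3000 nM to 20000 nM.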

Compound 4, half-maximal inhibitory concentration: 6700 nM
Compound 4: middle estimate off by 1.2-fold (0.08 log units), on the high side; low and high end bracket the measured number.
By their numbers in this assay, from the lowest: compound 3; then compounds 4, 2 and 1 (each within the scatter of the next, the first and the last beyond it).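

In this assay, putting 3-methylphenyl in place of thiophen-2-yl on a carbonyl carbon gives a 2.1-fold lower number from compound 1 to compound 4 (0.33 log units; beyond the scatter), a modest step and the only one here that can be read as a change in a single place. It shows that this position tolerates the exchange of a five-membered aromatic ring with one hetero atom for a six-membered aromatic ring of carbon only, and that the number falls rather than rises with this exchange. Nothing measured here explains the step.

Still open, on these data alone, is how much of the step belongs to the six-membered ring and how much to its methyl group, a split that a plain phenyl group could show. Equally open, as far as these compounds go, is how an amine or a carboxylic acid in place of that methyl group would read in this assay at this position.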